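Swapping the Aryl Tail: Indole Enters at Compound 4

The source may hold more compounds than are shown below. What is called first, only, known or untested is meant among the compounds shown, and "the series" means these compounds.

Three measured compounds share one core and differ only in the aromatic group at the end of the amide chain. Compound 1 `CC(C)C[C@H](N)c1cc(C(F)(F)F)ccc1N1CCN(C(=O)CCc2cccc(C(F)(F)F)c2)CC1` gives 2200 nM in an assay on HEK293 cells for displacement of a labelled ligand from Melanocortin receptor 4 (Homo sapiens); a lower number here means a stronger inhibitor, a higher number a weaker inhibitor. Compound 2 `COc1cccc(CCC(=O)N2CCN(c3ccc(C(F)(F)F)cc3[C@@H](N)CC(C)C)CC2)c1` gives 4000 nM. Compound 3 `COc1ccc(OC)c(CCC(=O)N2CCN(c3ccc(C(F)(F)F)cc3[C@@H](N)CC(C)C)CC2)c1` gives 2500 nM. Among these three numbers, compound 3 holds the second highest, but its gaps to compound 1 and compound 2 both stay within the scatter. The unmeasured compound 4 `CC(C)C[C@H](N)c1cc(C(F)(F)F)ccc1N1CCN(C(=O)CCc2c[nH]c3ccccc23)CC1` differs from compound 3 by 1H-indol-3-yl in place of 2,5-dimethoxyphenyl on a saturated chain carbon, two bonds along the chain from a carbonyl carbon. For the measured compounds named here, the step of a 1.1-fold higher number from compound 1 to compound 3 (0.06 log units; within the scatter) is the one earlier change at this position, and the steps of a 1.8-fold higher number from compound 1 to compound 2 (0.26 log units; within the scatter) and a 1.6-fold lower number from compound 2 to compound 3 (0.20 log units; within the scatter) on the same ring were just as small. On that basis the change is expected to give no change at the digits printed from compound 3 to compound 4 (within the scatter). Compound 4 is estimated at 2500 nM, with a range from 800 nM to 8000 nM.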

Compound 4, inhibition constant: 640 nM
Compound 4: middle estimate off by 3.9-fold (0.59 log units), on the high side, outside the stated range (below it).
By their numbers in this assay, from the lowest: compound 4; then compounds 1, 3 and 2 (each within the scatter of the next).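

Until now every swap at this position stayed within the scatter, so the aromatic tail seemed to matter little, but 1H-indol-3-yl moves the number beyond it, with a 3.9-fold lower number from compound 3 to compound 4 (0.59 log units; beyond the scatter) and a 6.3-fold lower number from compound 2 to compound 4 (0.80 log units; beyond the scatter) and a 3.4-fold lower number from compound 1 to compound 4 (0.54 log units; beyond the scatter) all pointing the same way. The three phenyl tails sit together in this assay while the indole stands apart from all of them. Nothing available explains this difference.

From the compounds shown here alone, it remains open whether 1-methyl-1H-indol-3-yl, which lacks the hydrogen-bond donor, would keep the lower number. The same holds for a longer chain carrying 1H-indol-3-yl.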